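The compounds below may be only part of what the source reports. "The series", "measured", "known", "first", "only" and "open" are said of these compounds alone.

In an ADME assay on Vero cells (Chlorocebus sabaeus) for cytotoxicity, read by MTT assay, with a stated time of 72 h (a higher number here means a weaker inhibitor, a lower number a stronger inhibitor), compound 3 `CCn1cc(C(=O)N2N=C(c3cc4ccccc4o3)CC2c2ccccc2OC)c(=O)c2ccc(C)nc21` gives only the limit of the measurement, > 187000 nM, not a number. Two related compounds behave the same way. Compound 1 `O=C(c1ccncc1)N1N=C(c2cc3ccccc3o2)CC1c1ccccc1O` reaches the limit > 195000 nM. Compound 2 `O=C(c1ccncc1)N1N=C(c2cc3ccccc3o2)CC1c1ccco1` reaches the limit > 208000 nM. Between these two lies a step that the two limits leave unreadable from compound 1 to compound 2, whose size cannot be read because both ends sit at a limit (the limit of > 195000 nM in this assay, at which 1 of the 3 values shown sits, and (the limit of > 208000 nM in this assay, at which 1 of the 3 values shown sits)). Compound 4 `CCn1cc(C(=O)N2N=C(c3cc4ccccc4o3)CC2/C=C/c2ccccc2)c(=O)c2ccc(C)nc21` differs from compound 3 by 2-phenylethenyl in place of 2-methoxyphenyl on a saturated ring carbon. Going by the values given here, no measured step offers a readable size, so nothing points to a shift beyond the scatter, and a further limit rather than a number seems the likely outcome. For compound 4 the change is expected to amount to a step that the limit leaves unreadable from compound 3 to compound 4. Compound 4 is estimated at 250000 nM, within 120000 nM to 500000 nM.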

Compound 4, half-maximal inhibitory concentration: > 168000 nM
Compound 4 gave a limit, no number (the forecaster's own chance of this, stated with the estimate: 80%); the middle value lies beyond the limit too.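

Compound 3 and compound 4 each give a limit rather than a number, so the step between them cannot be read. With every value at a limit, the compounds shown leave open how far any change of group on the saturated ring carbon moves the result.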